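The source may hold more compounds than are shown below. What is called first, only, known or untested is meant among the compounds shown, and "the series" means these compounds.

Measured compounds in the series:

compound 1 `CSc1ccc(CNc2nc(SC)nc3ncccc23)cc1` — in a functional assay on CCRF-CEM cells (Homo sapiens) for cytotoxicity, read by MTT assay, with a stated time of 72 h (on this read-out higher numbers stand for lower toxicity in this test and lower numbers for higher toxicity in this test), compound 1 gives 59000 nM
compound 2 `CSc1nc(NCCCc2ccccc2)c2ccccc2n1` — in this assay compound 2 gives > 100000 nM

For compound 2 the value in this assay is a limit of the assay, not a number (the limit of > 100000 nM in this assay, at which 1 of the 2 values shown sits). Going by the values given here, compound 1 therefore holds the only actual number in this assay; the other value of the two is a limit, so no ranking between them is drawn.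

The next compound, compound 3 `COc1ccc(CNc2nc(SC)nc3ncccc23)cc1`, differs from compound 1 in one place: methoxy in place of methylsulfanyl on an aromatic carbon. Among the compounds with values here, no measured pair in this set isolates such an exchange, so the step has no precedent here. A step from compound 1 to compound 3 within the usual scatter is expected, with no direction beyond it, which is what a 1.1-fold higher number from compound 1 to compound 3 (0.04 log units; within the scatter) means. For compound 3 the estimated value in this assay is 65000 nM, expected between 28000 nM and 150000 nM.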

Compound 3, concentration lethal to 50% of the cells: > 100000 nM
Compound 3: a limit, no number (the forecaster's own chance of this, stated with the estimate: 30%); at least 1.5-fold (0.18 log units) between middle value and limit.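

In this assay compound 3 stands at a limit of the assay, > 100000 nM, and not at a number. Methoxy in place of methylsulfanyl gives an at least 1.6-fold higher number from compound 1 to compound 3 (0.22 log units; that floor lies within the scatter), the first measured pair at this position; only a floor is known, so the real size of the step stays unread and the change cannot be told apart from the scatter. The ceiling of the assay now governs most of the series: the limit of > 100000 nM in this assay, at which 2 of the 3 values shown sit.

With only methylsulfanyl and methoxy at this position, and compound 1 as the only actual number, the compounds shown do not tell how far this place can move the read-out. Going by these compounds, whether a chlorine atom, an amine or a carboxylic acid on the same aromatic carbon would give a lower number remains open.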